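Working notes on the step from compound 2 to compound 3

The source may hold more compounds than are shown below. What is called first, only, known or untested is meant among the compounds shown, and "the series" means these compounds.

Compound 2 `COC(=O)[C@@H](NC(=O)c1[nH]cnc1C(=O)Nc1ccc(Cl)c(Cl)c1)C(C)C` stands at the edge of what a functional assay on HL-60 cells (Homo sapiens), with a stated time of 4 days (a lower number here means a stronger inhibitor, a higher number a weaker inhibitor), reports: in this assay compound 2 gives > 62500 nM, which is a limit of the assay and not a number. Its stereoisomer, compound 1 `COC(=O)[C@H](NC(=O)c1[nH]cnc1C(=O)Nc1ccc(Cl)c(Cl)c1)C(C)C`, in this assay gives 4900 nM. Within the data shown here, the only measured step is an at least 12-fold higher number from compound 1 to compound 2 (1.10 log units; beyond the scatter), and it rests on the fact that compounds 1 and 2 differ only in the configuration as drawn together with the limit of > 62500 nM in this assay, at which 1 of the 2 values shown sits.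

Compound 3 `CCCN(CCC)C(=O)c1[nH]cnc1C(=O)Nc1ccc(Cl)c(Cl)c1` differs from compound 2 by dipropylamino in place of (1-(methoxycarbonyl)-2-methylpropyl)amino on a carbonyl carbon. Among the measured compounds shown here, no measured step bears on this replacement; the stereo step concerns only the outgoing group, and the starting point is a limit rather than a number. The step of an at least 2.5-fold lower number from compound 2 to compound 3 (0.39 log units; beyond the scatter) is therefore expected with wide uncertainty, and a return to a measurable number cannot be counted on. Compound 3 is estimated at 25000 nM in this assay, within 3000 nM to 200000 nM.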

Compound 3, half-maximal inhibitory concentration: 38900 nM
For compound 3 the middle estimate is 1.6-fold (0.19 log units) below the measured one, within the range that was stated.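

In this assay, dipropylamino on a carbonyl carbon gives a value that is a number, not a limit: compound 3 gives 38900 nM. The replacement does not match the (1-(methoxycarbonyl)-2-methylpropyl)amino group in its better configuration, as the comparison shows a 7.9-fold higher number from compound 1 to compound 3 (0.90 log units; beyond the scatter). Against the other configuration only a floor can be read, an at least 1.6-fold lower number from compound 2 to compound 3 (0.20 log units; that floor lies within the scatter), and the true size of that step stays open because its starting value is a limit of the assay: the limit of > 62500 nM in this assay, at which 1 of the 3 values shown sits.

The replacement removes the amide hydrogen, the methyl ester and the stereocentre together, so the compounds shown leave open which of these changes accounts for the difference from compound 1. A carboxylic acid in place of the methyl ester, or diethylamino on the same carbonyl carbon, would test this more narrowly.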